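Arylamine variants of the shared core: the next step

The source may report more compounds than this note shows. Statements on the series, on what has been measured and on what is new or still open speak of the compounds shown alone.

compound 1 `CN(C)C(=S)N/N=C/c1ccc2ccccc2n1` — 20 nM
compound 2 `Fc1ccccc1NC(=S)N/N=C/c1ccc2ccccc2n1` — > 100000 nM

In a functional assay on HT-29 cells (Homo sapiens) for antiproliferative activity, read by sulforhodamine B assay, with a stated time of 72 h (a higher number here means a weaker inhibitor, a lower number a stronger inhibitor), compound 1 gives 20 nM. Compound 2 carries a 2-fluorophenyl on the amide-type nitrogen in place of the dimethyl group of compound 1. In this assay compound 2 returns only a limit, > 100000 nM. Compound 2 therefore sits at the limit of > 100000 nM in this assay, at which 1 of the 2 values shown sits, and has no number of its own, so its distance from compound 1 cannot be stated beyond the fact that the two values lie far apart.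

Compound 3 `COc1cccc(NC(=S)N/N=C/c2ccc3ccccc3n2)c1` is the next step from compound 2: 3-methoxyphenyl in place of 2-fluorophenyl on an amide-type nitrogen. For the measured compounds named here, no measured pair shows this change. Since compound 2 is already at the limit, the expected step from compound 2 to compound 3 in this assay is a number no higher from compound 2 to compound 3 (the limit leaves the size open), that is, none beyond the scatter, with a second limit the most likely outcome. For compound 3 the estimate in this assay is 100000 nM, within 20000 nM to 300000 nM.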

Compound 3, half-maximal inhibitory concentration: 82400 nM
For compound 3 the middle estimate is 1.2-fold (0.08 log units) above the measured one; low and high end bracket the measured number.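

In this assay, 3-methoxyphenyl on the amide-type nitrogen yields a measured number rather than a limit: compound 3 gives 82400 nM, still a much higher number than compound 1 at 20 nM. On these data alone, the step reads an at least 1.2-fold lower number from compound 2 to compound 3 (0.08 log units; that floor lies within the scatter), so this floor alone shows no change beyond the scatter, and the true size of the step stays open. Compound 2 itself remains a limit and not a number: the limit of > 100000 nM in this assay, at which 1 of the 3 values shown sits.

The compounds shown leave open whether the high numbers extend to aryl groups on this nitrogen generally, since only 2-fluorophenyl and 3-methoxyphenyl appear here. They also leave open whether a single methyl, a benzyl group or a morpholine ring in this place would stay close to compound 1 or fall with the aryl compounds.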